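Benzoxazole for benzothiazole on the amide-bearing ring

The source may report more compounds than this note shows. Statements on the series, on what has been measured and on what is new or still open speak of the compounds shown alone.

Measured so far:
- compound 1, `COc1ccc(-c2nc3ccccc3s2)cc1NC(=O)c1cc([N+](=O)[O-])ccc1Cl`: "below limit of detection" (no number reported)
- compound 2, `O=C(Nc1cc(-c2nc3ccccc3s2)ccc1Cl)c1cc([N+](=O)[O-])ccc1Cl`: "below limit of detection" (no number reported)
- compound 3, `O=C(Nc1cc(-c2nc3ccccc3s2)ccc1F)c1cc([N+](=O)[O-])ccc1Cl`: 191 10^-6 cm/s

In an ADME assay for permeability, using PAMPA, at pH 7.4 (a lower number here means that the compound crosses the layer more slowly, a higher number that the compound crosses the layer faster), compound 1 gives "below limit of detection" (no number reported). Compound 2 likewise gives "below limit of detection" (no number reported) in this assay. Within the data shown here, compound 3 is thus the only member of the series with a number in this assay, where compound 3 gives 191 10^-6 cm/s; the other two entries carry no single number, so no step between measured compounds can be computed here.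

The next compound, compound 4, `O=C(Nc1cc(-c2nc3ccccc3o2)ccc1F)c1cc([N+](=O)[O-])ccc1Cl`, differs from compound 3 in one place: 1,3-benzoxazol-2-yl in place of 1,3-benzothiazol-2-yl on an aromatic carbon. The 1,3-benzoxazol-2-yl group keeps the same count of heavy atoms, hydrogen-bond donors and hydrogen-bond acceptors as the 1,3-benzothiazol-2-yl group it replaces, and nothing measured in this series speaks to this exchange. The expectation is therefore a step from compound 3 to compound 4 of a 1.3-fold lower number from compound 3 to compound 4 (0.10 log units; within the scatter), within the usual scatter or a small downward move beyond it. For compound 4 the estimate in this assay is 150 10^-6 cm/s, with a range from 60 10^-6 cm/s to 300 10^-6 cm/s.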

Compound 4, apparent permeability: 214 10^-6 cm/s
Estimate against measurement, compound 4: 1.4-fold (0.15 log units) below; measured number inside the range.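

In this assay, among these compounds, placing 1,3-benzoxazol-2-yl instead of 1,3-benzothiazol-2-yl on this aromatic carbon, para to a fluoro group, gives a 1.1-fold higher number from compound 3 to compound 4 (0.05 log units; within the scatter), the first step with a number at both ends. At this position, with the fluoro group in place, the read-out does not distinguish the two groups, so the ring oxygen and ring sulfur are interchangeable here as far as this measurement goes. No measured property in hand accounts for this result.

As far as these compounds go, whether the exchange behaves the same way alongside the chloro group of compound 2 or the methoxy group of compound 1 remains open. Also open, from the compounds shown here alone, is how the read-out responds at the other end of the molecule, for example with an amine or a carboxylic acid in place of the nitro group.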